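A few compounds are considered here, and "the series" means these few. Any claim that something is new, unique, unknown or untested is made for them only; others in the source may bear on it.

Going by the values given here, compound 1 `Nc1cc(N)c2nc(-c3ccccc3)c(Oc3ccc(Cl)c(Cl)c3)nc2c1` is the only compound here with a numerical result: in a functional assay on NCI-H460 cells (Homo sapiens) for inhibition, read by sulforhodamine B assay, with a stated time of 48 h (on this read-out higher numbers stand for weaker inhibition of growth and lower numbers for stronger inhibition of growth), compound 1 gives 70800 nM. Compound 2 `CCOC(=O)[C@H](CCC(=O)O)NC(=O)c1ccc(CNc2nc3cc(N)cc(N)c3nc2-c2ccccc2)cc1` reaches only a limit of the assay; in this assay compound 2 gives < 100000 nM, which is a limit and not a number. Among the compounds with values here, this is the one other value shown, (the limit of < 100000 nM in this assay, at which 1 of the 2 values shown sits). Compound 3 `Nc1cc(N)c2nc(-c3ccccc3)c(Sc3ccc(F)cc3)nc2c1` differs from compound 1 in a single place: (4-fluorophenyl)sulfanyl in place of 3,4-dichlorophenoxy on an aromatic carbon. Within the data shown here, no step between two measured compounds is available, so there is no measured pair from which the size of this change could be read. The step is expected to stay within the usual scatter, in either direction, a 1.2-fold lower number from compound 1 to compound 3 (0.07 log units; within the scatter). Compound 3 is accordingly estimated at 60000 nM in this assay, with a range from 20000 nM to 200000 nM.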

Compound 3, concentration for total growth inhibition: 66100 nM
Beside the measured number, compound 3's estimate is 1.1-fold (0.04 log units) below it; measured number inside the range.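

Going by these compounds alone, the first measured step at this position, on an aromatic carbon next to the ring nitrogen and ortho to a phenyl group, comes in this assay (a 1.1-fold lower number from compound 1 to compound 3 (0.03 log units; within the scatter)). Compound 1 and compound 3 therefore cannot be told apart on this read-out, even though oxygen gives way to sulfur and two chlorine atoms give way to one fluorine in the same exchange. Nothing shown here accounts for this result.

Within the data shown here, with these changes made together, the single step does not separate the effect of the sulfur from that of the fluorine. As far as these compounds go, it also remains open whether an amine, a carboxylic acid or a longer alkyl chain on this carbon would move the number beyond the usual scatter.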